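The compounds below may be only part of what the source reports. "The series", "measured", "known", "first", "only" and "open" are said of these compounds alone.

Two compounds share one core and differ only in the aromatic group attached to the exocyclic double bond. Compound 1 `COc1ccc(/C=C2\S/C(=N\c3csc(-c4ccc(Cl)cc4)c3)NC2=O)cc1` carries a 4-methoxyphenyl there, and in a functional assay on MDA-MB-231 cells (Homo sapiens) for cytotoxicity, read by MTT assay, with a stated time of 72 h (a lower number here means a stronger inhibitor, a higher number a weaker inhibitor), compound 1 gives 1200 nM. Compound 2 `O=C1N/C(=N/c2csc(-c3ccc(Cl)cc3)c2)S/C1=C\c1ccc(Br)cc1` carries a 4-bromophenyl instead, and in this assay compound 2 gives 3500 nM. For the measured compounds named here, the single measured step, a 2.9-fold higher number from compound 1 to compound 2 (0.46 log units; beyond the scatter), thus shows that exchanging methoxy for bromo weakened the inhibition to a modest but real degree. Among the two numbers so far, compound 2 stands at the higher, weaker end.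

Compound 3 `COc1ccc(/C=C2\S/C(=N\c3csc(-c4ccc(Cl)cc4)c3)NC2=O)cc1OC` has not yet been measured. The change from compound 2 to compound 3 is 3,4-dimethoxyphenyl in place of 4-bromophenyl on a double-bonded chain carbon bound to a double-bonded ring carbon. Part of this change simply reverses the measured step: a methoxy returns in place of the bromo, which by itself would be expected to bring the number back toward that of compound 1. Going by the values given here, what the second methoxy adds is unknown, as no measured pair isolates it. On that basis the step of a 2.7-fold lower number from compound 2 to compound 3 (0.43 log units; beyond the scatter) is expected, a drop of roughly the size already seen. For compound 3 the estimate in this assay is 1300 nM, within a range from 400 nM to 4500 nM.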

Compound 3, half-maximal inhibitory concentration: 1900 nM
Compound 3: middle estimate off by 1.5-fold (0.16 log units), on the low side, and the stated range covers the measured number.
By their numbers in this assay, from the lowest: compounds 1, 3 and 2 (each within the scatter of the next, the first and the last beyond it).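

In this assay the step of a 1.8-fold lower number from compound 2 to compound 3 (0.27 log units; within the scatter) stays inside the usual scatter, so at this place, on a double-bonded chain carbon bound to a double-bonded ring carbon, 3,4-dimethoxyphenyl and 4-bromophenyl cannot be told apart, even though the group that enters is larger by the heavy-atom count and brings two hydrogen-bond acceptors that 4-bromophenyl lacks. For the compounds shown here, the second methoxy, which no earlier pair isolated, can now be read on its own: the step of a 1.6-fold higher number from compound 1 to compound 3 (0.20 log units; within the scatter) is also within the scatter, so methoxy in place of hydrogen on an aromatic carbon leaves no clear mark on the number, and the only gap beyond the scatter among the three remains the one between compound 1 and compound 2. No measured evidence comes with these numbers that could explain how these groups act.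

On these data alone, what an amine or a carboxylic acid on this aromatic ring would do, or a longer chain in place of methoxy, stays open. Whether the gap between compound 1 and compound 2 would hold on other cell types also stays open, since this assay is the only read-out shown.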